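Replacing 2,4-difluorophenyl with 4-hydroxyphenyl in a growth inhibitor

The compounds below may be only part of what the source reports. "The series", "measured", "known", "first", "only" and "open" are said of these compounds alone.

Of the compounds shown here, two sharing one core have been measured in a functional assay on ACHN cells (Homo sapiens); on this read-out higher numbers stand for weaker inhibition of growth and lower numbers for stronger inhibition of growth. Compound 1 `O=S(=O)(/C=C/c1ccc(Br)cc1)Cc1ccc(Nc2ncnc3ccccc23)cc1` gives 200 nM, and compound 2 `O=S(=O)(/C=C/c1ccc(F)cc1F)Cc1ccc(Nc2ncnc3ccccc23)cc1` gives 31000 nM, the higher of the two numbers and so the weaker inhibition of growth. Among the compounds with values here, only one group separates them, yet exchanging 4-bromophenyl for 2,4-difluorophenyl produces a large change: a 160-fold higher number from compound 1 to compound 2 (2.19 log units; beyond the scatter). Compound 3 `O=S(=O)(/C=C/c1ccc(O)cc1)Cc1ccc(Nc2ncnc3ccccc23)cc1` keeps the core and changes the group at that same place, on a double-bonded chain carbon bound to a double-bonded chain carbon: 4-hydroxyphenyl in place of 2,4-difluorophenyl on a double-bonded chain carbon bound to a double-bonded chain carbon.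

Within the data shown here, this single measured step is the only guide, and it shows that this assay can respond strongly to a change at this place. Among the measured compounds shown here, no measured compound carries 4-hydroxyphenyl, so the size of the next step remains uncertain. Compound 3 has no fluorine, and neither does compound 1, at 200 nM, so a sizeable move toward lower numbers is expected, probably stopping short of compound 1. The estimated step is a 12-fold lower number from compound 2 to compound 3 (1.09 log units; beyond the scatter). The estimate for compound 3 is 2500 nM, with an expected range of 350 nM to 18000 nM.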

Compound 3, concentration for 50% growth inhibition: 20 nM
For compound 3 the middle estimate is 130-fold (2.10 log units) above the measured one, outside the stated range (below it).
By their numbers in this assay, from the lowest: compound 3; then compound 1; then compound 2.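

In this assay this place on a double-bonded chain carbon bound to a double-bonded chain carbon turns out to have a far wider span than the first pair showed, since 4-hydroxyphenyl in place of 2,4-difluorophenyl brings a 1600-fold lower number from compound 2 to compound 3 (3.19 log units; beyond the scatter) in a single exchange. Compound 1 is also no longer the lowest number of the set: hydroxy in place of bromo on an aromatic carbon gives a 10-fold lower number from compound 1 to compound 3 (1.00 log units; beyond the scatter) as a further, modest gain, so two rings without fluorine can still differ clearly. Nothing available explains why these exchanges have such large effects.

From the compounds shown here alone, whether the hydroxy group itself is what counts stays open, and a methoxy group or an amine in its place on the ring would be the natural comparison. Also open, going by these compounds, is how much of the high number of compound 2 belongs to the two fluorines and how much to the missing group in the position named by 4-hydroxyphenyl, which a plain phenyl ring or a 4-fluorophenyl ring would help to separate.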